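Cyclopropyloxy in place of 2,4-difluorophenoxy: working notes

The compounds below may be only part of what the source reports. "The series", "measured", "known", "first", "only" and "open" are said of these compounds alone.

Measured in a functional assay on MV4-11 cells (Homo sapiens) for antiproliferative activity, read by CCK-8 assay, with a stated time of 72 h; on this read-out higher numbers stand for weaker inhibition and lower numbers for stronger inhibition:
- compound 1 `Cn1cc(-c2cccc(C(C)(C)O)c2)c2cc(C(=O)NCc3ccc(C(=O)Nc4ccccc4N)cc3)[nH]c2c1=O`: 2200 nM
- compound 2 `Cn1cc(-c2cc(C(C)(C)O)ccc2Oc2ccc(F)cc2F)c2cc(C(=O)NCc3ccc(C(=O)Nc4ccccc4N)cc3)[nH]c2c1=O`: 90 nM

Compound 2 has the lower number of the two measured compounds. The next compound, compound 3 `Cn1cc(-c2cc(C(C)(C)O)ccc2OC2CC2)c2cc(C(=O)NCc3ccc(C(=O)Nc4ccccc4N)cc3)[nH]c2c1=O`, differs from it as follows: cyclopropyl in place of 2,4-difluorophenyl on an oxygen on an aromatic ring. In short, cyclopropyl stands in place of 2,4-difluorophenyl on an oxygen on an aromatic ring, so 2,4-difluorophenoxy becomes cyclopropyloxy.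

Among the compounds with values here, one measured step bears on this: a 24-fold lower number from compound 1 to compound 2 (1.39 log units; beyond the scatter), a large step on adding 2,4-difluorophenoxy in place of hydrogen on an aromatic carbon. That step adds the whole group, and nothing measured separates the oxygen from the ring it carries. Part of that gain is therefore expected to survive, with a moderate loss in this assay.

The expected change is a 2.8-fold higher number from compound 2 to compound 3 (0.44 log units; beyond the scatter). For compound 3 the estimated value is 250 nM, with an expected range of 80 nM to 800 nM.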

Compound 3, half-maximal inhibitory concentration: 40 nM
Compound 3: the middle estimate sits 6.3-fold (0.80 log units) above what was measured, outside the stated range (below it).
By their numbers in this assay, from the lowest: compound 3; then compound 2; then compound 1.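

In this assay, an aromatic ring on the oxygen is not required at this position: cyclopropyl in place of 2,4-difluorophenyl gives a 2.3-fold lower number from compound 2 to compound 3 (0.35 log units; beyond the scatter), a modest gain with fewer heavy atoms on the oxygen. Measured against hydrogen on the aromatic carbon, cyclopropyloxy gives a 55-fold lower number from compound 1 to compound 3 (1.74 log units; beyond the scatter), so the large gain at this position does not depend on the 2,4-difluorophenyl ring. Nothing available explains why the cyclopropyl compound has the lower number.

The compounds shown leave open how much of the gain belongs to the oxygen and how much to the group it carries, a question that a cyclopropyl group bonded directly to the aromatic carbon would address. As far as these compounds go, it also remains open whether a methoxy or cyclobutyloxy group would continue or reverse the change seen with cyclopropyloxy.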